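This account rests on a few compounds, and the source may have more. Where it says the series, first, only, none or still open, it means among the compounds named here.

The measured compounds: compound 1 `O=C(COc1cccc2ccccc12)N/N=C/c1c(O)ccc2ccccc12` gives 2.12 ug/mL; compound 2 `Cc1ccc(/C=N/NC(=O)COc2cccc3ccccc23)cc1` gives 83.9 ug/mL; compound 3 `C/C(=N\NC(=O)COc1cccc2ccccc12)c1ccc(O)cc1O` gives 59.9 ug/mL.

All three were tested in an ADME assay on MT4 cells (Homo sapiens) for cytotoxicity, read by MTT assay, with a stated time of 4 days; a lower number here means that less compound is tolerated, a higher number that more compound is tolerated. Compound 3 gives the second highest of the three numbers: compound 2 sits within the scatter of it, while compound 1 lies far lower, beyond the scatter. Compound 4 `C/C(=N\NC(=O)COc1cccc2ccccc12)c1ccc([N+](=O)[O-])cc1` has not yet been measured. It differs from compound 3 in one place: 4-nitrophenyl in place of 2,4-dihydroxyphenyl on a carbon with a double bond to nitrogen. Within the data shown here, no pair of measured compounds shows this change, so the step has to be guessed. Given that compound 2 and compound 3 are within the scatter of each other, no step beyond the scatter is expected. The expected step is a 1.2-fold lower number from compound 3 to compound 4 (0.08 log units; within the scatter). Compound 4 is accordingly estimated at 50 ug/mL, with a range from 15 ug/mL to 130 ug/mL.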

Compound 4, half-maximal cytotoxic concentration: 89.3 ug/mL
Estimate against measurement, compound 4: 1.8-fold (0.25 log units) below; the measured number falls inside the stated range.
By their numbers in this assay, from the lowest: compound 1; then compounds 3, 2 and 4 (each within the scatter of the next).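

On a carbon with a double bond to nitrogen, 4-nitrophenyl in place of 2,4-dihydroxyphenyl gives a 1.5-fold higher number from compound 3 to compound 4 (0.17 log units; within the scatter) in this assay and so moves the number by no more than the scatter. The 2 hydrogen-bond donors counted on 2,4-dihydroxyphenyl can therefore leave this position without a step beyond the scatter in this assay. No measured property is available to explain this step. From the compounds shown here alone, whether an amine or a carboxylic acid at this position would also stay within the scatter remains open. So does the outcome of a longer chain in place of the saturated chain carbon.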